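The compounds below may be only part of what the source reports. "The series", "measured", "known", "first", "only" and "open" are said of these compounds alone.

Compound 1 `COc1ccc(C(=O)Nc2nc3c(OC)cccc3s2)cc1` carries a methoxy group on one aromatic ring of the shared core; in a functional assay on MDA-MB-231 cells (Homo sapiens) for antiproliferative activity, read by sulforhodamine B assay (a higher number here means a weaker inhibitor of growth, a lower number a stronger inhibitor of growth), compound 1 gives 1.25 ug/mL. Compound 2 `COc1cccc2sc(NC(=O)c3ccc(C#N)cc3)nc12` carries a cyano group in that place instead. In this assay compound 2 gives > 10 ug/mL, which is a limit of the assay rather than a measured number. For the measured compounds named here, the step of an at least 8.0-fold higher number from compound 1 to compound 2 (0.90 log units; beyond the scatter) is the only measured comparison available. Compound 3 `COc1cccc2sc(NC(=O)c3ccc([N+](=O)[O-])cc3)nc12` differs from compound 2 by nitro in place of cyano on an aromatic carbon, a nitro in place of cyano on an aromatic carbon. Going by the values given here, no measured step covers a nitro group, so the step that the limit leaves unreadable from compound 2 to compound 3 is expected to stay within the scatter. Compound 3 is therefore expected to give 12 ug/mL, between 3 ug/mL and 40 ug/mL, quite possibly again only a limit.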

Compound 3, concentration for 50% growth inhibition: > 10 ug/mL
Compound 3: a limit, no number; the forecaster's own chance of this, stated with the estimate: 60%; the middle value does not contradict the limit.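

Nitro in place of methoxy on this carbon gives an at least 8.0-fold higher number from compound 1 to compound 3 (0.90 log units; beyond the scatter) in this assay, so the loss seen with cyano is not confined to that one group. Of the three groups shown at this place, only methoxy gives a value that is not a limit. The step between compound 2 and compound 3 cannot be read, because both compounds sit at the same limit: the limit of > 10 ug/mL in this assay, at which 2 of the 3 values shown sit.

Going by these compounds, how far cyano and nitro lie past that limit remains open. So does whether an amine, a hydroxyl or a methyl at this place would give a measurable value, as methoxy does.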